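This account rests on a few compounds, and the source may have more. Where it says the series, first, only, none or still open, it means among the compounds named here.

Among the three compounds whose numbers are known, compound 3 `Brc1ccc2[nH]c(-c3cncn3CC3CCCCN3)cc2c1` sits with the second highest value: in an assay on HEK293 cells for inhibition of Indoleamine 2,3-dioxygenase 1 (Homo sapiens), with a stated time of 30 min (on this read-out higher numbers stand for an effect only at larger amounts of compound and lower numbers for an effect already at smaller amounts), compound 3 gives 10700 nM. Its closest neighbour is compound 1 `Brc1ccc2[nH]c(-c3cncn3Cc3ccccc3)cc2c1`, which in this assay gives 11000 nM, and the step of a 1.0-fold lower number from compound 1 to compound 3 (0.01 log units; within the scatter) shows the two are not separated beyond the scatter. The third member, compound 2 `FC(F)(F)c1ccc(Cn2cncc2-c2cc3cc(Br)ccc3[nH]2)cc1`, in this assay gives 4590 nM; the step of a 2.4-fold lower number from compound 1 to compound 2 (0.38 log units; beyond the scatter) is a modest one, and compound 2 lies below compound 3 by a margin beyond the scatter.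

Compound 4 `Oc1cccc(Cn2cncc2-c2cc3cc(Br)ccc3[nH]2)c1` has not been measured in this assay. It differs from compound 3 in one place: 3-hydroxyphenyl in place of piperidin-2-yl on a saturated chain carbon bound to an aromatic nitrogen. Among the measured compounds shown here, two measured steps bear on this change. The step of a 1.0-fold lower number from compound 1 to compound 3 (0.01 log units; within the scatter) shows that swapping phenyl for piperidin-2-yl on the saturated chain carbon bound to an aromatic nitrogen made no difference beyond the scatter, so the reverse move, from piperidin-2-yl back toward an aromatic ring, is expected to cost little. The step of a 2.4-fold lower number from compound 1 to compound 2 (0.38 log units; beyond the scatter) shows that a substituent on that aromatic ring can lower the number modestly. For the measured compounds named here, no compound carrying a hydroxyl on that ring has been measured, so the size of any effect from the hydroxyl is not known from these data.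

Compound 4 is therefore expected to land close to compound 3, perhaps slightly lower, with a step of a 1.3-fold lower number from compound 3 to compound 4 (0.13 log units; within the scatter). The estimate for compound 4 in this assay is 8000 nM, expected to fall between 3000 nM and 20000 nM.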

Compound 4, half-maximal effective concentration: 9970 nM
Beside the measured number, compound 4's estimate is 1.2-fold (0.10 log units) below it; the range from low to high includes it.
By their numbers in this assay, from the lowest: compound 2; then compounds 4, 3 and 1 (each within the scatter of the next).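

In this assay, the new result brings a substituted aromatic ring and a saturated ring into direct comparison on a saturated chain carbon bound to an aromatic nitrogen: a 1.1-fold lower number from compound 3 to compound 4 (0.03 log units; within the scatter) shows that 3-hydroxyphenyl and piperidin-2-yl are not separated. Hydroxy in place of hydrogen on an aromatic carbon also stays within the scatter, with a 1.1-fold lower number from compound 1 to compound 4 (0.04 log units; within the scatter), so a ring substituent does not by itself shift the number; compound 2 goes against any wider claim of tolerance, since trifluoromethyl gives a 2.4-fold lower number from compound 1 to compound 2 (0.38 log units; beyond the scatter), beyond the scatter. Nothing available explains why these groups give such similar numbers or why only trifluoromethyl stands apart.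

The compounds shown leave open whether the difference between compound 2 and compound 4 belongs to the groups themselves or to where they sit on the ring. They also leave open what an amine or a carboxylic acid on that ring would do, and whether a longer chain in place of the single saturated carbon would bring the number below that of compound 2.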